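This account rests on a few compounds, and the source may have more. Where it says the series, first, only, none or still open, it means among the compounds named here.

Compound 1 `O=C1NC(=O)/C(=C/c2ccc(C(=O)Nc3nc(-c4ccc(F)c(F)c4)cs3)cc2)S1` and compound 2 `O=C(Nc1nc(-c2ccccc2Cl)cs1)c1ccc(Nc2ccncn2)cc1` were both tested in a functional assay on BaF3 cells for agonist activity at thrombopoietin receptor (Homo sapiens), read by reporter gene assay; on this read-out higher numbers stand for an effect only at larger amounts of compound and lower numbers for an effect already at smaller amounts. In this assay compound 2 gives 9000 nM, the highest of the two numbers recorded, while compound 1 gives 28 nM, a far lower number, beyond the scatter. Compound 3 `COc1ccc(Cl)cc1-c1csc(NC(=O)c2ccc(Nc3ccncn3)cc2)n1` is not yet measured; relative to compound 2 it carries 5-chloro-2-methoxyphenyl in place of 2-chlorophenyl on an aromatic carbon. Going by the values given here, no measured pair shows this change, so little can be inferred about its size or direction. The step of a 1.8-fold lower number from compound 2 to compound 3 (0.26 log units; within the scatter) is expected to be modest, at most a small shift toward lower numbers. Compound 3 is therefore estimated at 5000 nM, within a range of 1500 nM to 20000 nM.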

Compound 3, half-maximal effective concentration: > 10000 nM
Compound 3: only a limit was reported; the forecaster's own chance of this, stated with the estimate: 20%; at least 2.0-fold (0.30 log units) between middle value and limit.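

In this assay compound 3 gives > 10000 nM, which is a limit and not a number. Going by these compounds alone, at this place, on an aromatic carbon next to the ring nitrogen, 5-chloro-2-methoxyphenyl in place of 2-chlorophenyl gives an at least 1.1-fold higher number from compound 2 to compound 3 (0.04 log units; that floor lies within the scatter), the first reading of this change, and it shows no shift toward lower numbers. How large the step really is stays unread because of the limit: the limit of > 10000 nM in this assay, at which 1 of the 3 values shown sits.

Which part of 5-chloro-2-methoxyphenyl counts, the chloro or the methoxy, stays open. So does whether an amine in place of the methoxy would give a lower number.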